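The compounds below may be only part of what the source reports. "The series", "measured", "known", "first", "only" and "open" are said of these compounds alone.

- Compound 1 `Cc1ccc(-c2nn(-c3ccccc3)cc2C(Nc2nc3cc(C)c(C)cc3s2)c2c(O)ccc3ccccc23)cc1`: 17800 nM
- Compound 2 `Oc1ccc2ccccc2c1C(Nc1nc2ccccc2s1)c1cn(-c2ccccc2)nc1-c1cccc(Cl)c1`: 6830 nM
- Compound 3 `COc1ccc2nc(NC(c3cn(-c4ccccc4)nc3-c3ccc(Cl)cc3)c3c(O)ccc4ccccc34)sc2c1`: 5200 nM

These values all come from a functional assay on HeLa cells (Homo sapiens) for antiproliferative activity, read by MTT assay, with a stated time of 48 h; a lower number here means a stronger inhibitor, a higher number a weaker inhibitor. There, compound 3 gives 5200 nM, a number within the scatter of compound 2 and clearly lower than that of compound 1.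

The next compound to be tested, compound 4 `COc1ccc2nc(NC(c3cn(-c4ccccc4)nc3-c3ccccc3)c3c(O)ccc4ccccc34)sc2c1`, changes compound 3 in one place. It has hydrogen in place of chloro on an aromatic carbon, so a 4-chlorophenyl becomes phenyl (hydrogen in place of chloro on an aromatic carbon).

Going by the values given here, no measured pair of compounds isolates this change. Compound 1 also lacks chloro, but it differs from compound 3 in more than one place, so the value of compound 1 17800 nM cannot be tied to chloro alone. It gives only a weak hint that a compound without chloro may show a higher number. In this assay, the expected result is therefore a small rise that stays within the scatter, estimated as a 1.4-fold higher number from compound 3 to compound 4 (0.16 log units; within the scatter). For compound 4, the estimated value is 7500 nM, with an expected range of 3000 nM to 19000 nM.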

Compound 4, half-maximal inhibitory concentration: 8290 nM
Estimate against measurement, compound 4: 1.1-fold (0.04 log units) below; the measured number falls inside the stated range.
By their numbers in this assay, from the lowest: compounds 3, 2 and 4 (each within the scatter of the next); then compound 1.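

Going by these compounds alone, this is the first pair of compounds in which chloro alone differs, so the step can be tied to this one change. In this assay, going from 4-chlorophenyl to phenyl gives a 1.6-fold higher number from compound 3 to compound 4 (0.20 log units; within the scatter), so at this place on the ring the chloro can be lost without a change that can be told from the usual scatter. Nothing measured on these compounds gives a reason for this result.

On these data alone, the comparison covers only chloro and hydrogen, so whether a larger or very different group on the same aromatic carbon, such as an amine or a carboxylic acid, would move the number beyond the scatter remains open. As far as these compounds go, it is also open whether this swap would behave the same way with other groups elsewhere on the shared core.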